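This account rests on a few compounds, and the source may have more. Where it says the series, first, only, none or still open, it means among the compounds named here.

Measured so far:
- compound 1, `CCN(C)C(=O)N1CCN(C(=S)SCc2cn(Cc3ccccc3F)nn2)CC1`, 5860 nM in a functional assay on MGC-803 cells (Homo sapiens) for cytotoxicity, read by MTT assay, with a stated time of 72 h; on this read-out higher numbers stand for weaker inhibition and lower numbers for stronger inhibition
- compound 2, `Cc1ccc(Cn2cc(CSC(=S)N3CCN(C(N)=O)CC3)nn2)cc1`, 29900 nM in this assay

Compound 2 stands at the highest of the two numbers; its nearest neighbour is compound 1, whose number is lower by a margin that is beyond the usual scatter. The two compounds differ in more than one place, so nothing is said here about which part of the structure accounts for the gap.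

Compound 3, `CCN(C)C(=O)N1CCN(C(=S)SCc2cn(Cc3ccc(C)cc3)nn2)CC1`, remains to be measured in this assay. Against compound 2 the change is ethyl(methyl)amino in place of amino on a carbonyl carbon. The rest of the structure is kept, so compound 3 carries the carbamoyl side of compound 1 together with the benzyl side of compound 2.

Expected step from compound 2: a drop in the number, of moderate size, beyond the scatter, as a 3.0-fold lower number from compound 2 to compound 3 (0.48 log units; beyond the scatter), because compound 1, which shares the ethyl(methyl)carbamoyl group, gives 5860 nM. The benzyl side of compound 3 still differs from that of compound 1, so the expected number is not set as low as compound 1's. Compound 3 is estimated at 10000 nM, within a range from 3500 nM to 30000 nM.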

Compound 3, half-maximal inhibitory concentration: 8270 nM
Compound 3: the middle estimate sits 1.2-fold (0.08 log units) above what was measured; the range from low to high includes it.
By their numbers in this assay, from the lowest: compounds 1 and 3 (each within the scatter of the next); then compound 2.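

In this assay, the exchange of amino for ethyl(methyl)amino on a carbonyl carbon whose other neighbours are amide-type nitrogen in a ring can now be read on its own, with the 4-methylphenyl side held fixed: it gives a 3.6-fold lower number from compound 2 to compound 3 (0.56 log units; beyond the scatter), a modest step resting on this single pair. With the ethyl(methyl)carbamoyl group held fixed, 4-methylphenyl in place of 2-fluorophenyl on a saturated chain carbon bound to an aromatic nitrogen gives a 1.4-fold higher number from compound 1 to compound 3 (0.15 log units; within the scatter), so in this pair the aryl exchange stays inside the scatter, while the carbonyl-side exchange in the other pair lies beyond it. No measurement at hand accounts for either step.

Still open, on these data alone, is how the number responds when this carbonyl carbon carries methylamino, dimethylamino or diethylamino, which would show whether the step follows the size of the chain or merely the loss of the amide hydrogen. Also open, as far as these compounds go, is whether the amino to ethyl(methyl)amino step recurs with the 2-fluorophenyl side, since it has been read with 4-methylphenyl only.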